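Three Substituted Nucleosides and a Fourth Awaiting Measurement

The compounds below may be only part of what the source reports. "The series", "measured", "known", "first", "only" and "open" are said of these compounds alone.

Measured so far:
compound 1 `Nc1nc(O)c2c(n1)n(C1OC(CO)[C@@H](O)[C@H]1O)c(=O)n2C/C=C/c1ccccc1`, 103 uM
compound 2 `Nc1nc(O)c2c(n1)n(C1OC(CO)[C@@H](O)[C@H]1O)c(=O)n2CC(O)CSc1ccccc1`, 142 uM
compound 3 `CN(C)CCCn1c(=O)n(C2OC(CO)[C@@H](O)[C@H]2O)c2nc(N)nc(O)c21`, 194 uM

Three compounds share one core and differ only in the group on a saturated chain carbon bound to an aromatic nitrogen. In a functional assay (B cells) with Mus musculus as the target (a lower number here means that less compound is needed, a higher number that more compound is needed for the effect), compound 1 gives 103 uM, compound 2 gives 142 uM and compound 3 gives 194 uM. All three steps between them stay within the scatter: a 1.4-fold higher number from compound 1 to compound 2 (0.14 log units; within the scatter), a 1.9-fold higher number from compound 1 to compound 3 (0.27 log units; within the scatter) and a 1.4-fold higher number from compound 2 to compound 3 (0.14 log units; within the scatter). Compound 3 therefore has the highest number of the three, but its nearest neighbour, compound 2, and its furthest, compound 1, both lie within the scatter of it, so no order among them can be claimed.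

Compound 4 `N#Cc1cccc(Cn2c(=O)n(C3OC(CO)[C@@H](O)[C@H]3O)c3nc(N)nc(O)c32)c1` is the next step from compound 3: 3-cyanophenyl in place of 2-(dimethylamino)ethyl on a saturated chain carbon bound to an aromatic nitrogen. Among the measured compounds shown here, no measured step exchanges an aminoalkyl chain for an aryl group at this position. The nearest guide is that three rather different groups at the same place, a 2-phenylethenyl, a 1-hydroxy-2-(phenylsulfanyl)ethyl and a 2-(dimethylamino)ethyl, all gave numbers within the scatter of one another. On that basis compound 4 is expected to give a step of a 1.3-fold lower number from compound 3 to compound 4 (0.11 log units; within the scatter), that is none beyond the scatter. The estimate for compound 4 is 150 uM, with a range from 60 uM to 400 uM.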

Compound 4, concentration for half-maximal effect: 3 uM
Estimate against measurement, compound 4: 50-fold (1.70 log units) above; the measured number lies below the stated range.
By their numbers in this assay, from the lowest: compound 4; then compounds 1, 2 and 3 (each within the scatter of the next).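

In this assay, the place on a saturated chain carbon bound to an aromatic nitrogen turns out not to be as tolerant of exchange as the first three compounds suggested: 3-cyanophenyl in place of 2-(dimethylamino)ethyl brings a 65-fold lower number from compound 3 to compound 4 (1.81 log units; beyond the scatter), in place of 1-hydroxy-2-(phenylsulfanyl)ethyl it brings a 47-fold lower number from compound 2 to compound 4 (1.68 log units; beyond the scatter), and in place of 2-phenylethenyl it brings a 34-fold lower number from compound 1 to compound 4 (1.54 log units; beyond the scatter). Compound 4 is therefore the only one of the four whose steps to all the others lie beyond the scatter, and an aromatic ring in the group is not sufficient for such a step, as compound 1 and compound 2 also carry a phenyl ring yet stay within the scatter of compound 3. Nothing available here bears on the reason for this large step.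

From the compounds shown here alone, what a plain benzyl group would give at this place remains open, and with it whether the step belongs to the nitrile or to the ring. Also open, going by these compounds, is whether a 3-chlorobenzyl or a 3-carboxybenzyl group would keep the number as low as that of compound 4.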